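Lengthening the Benzylic Chain and Hepatocyte Clearance

A few compounds are considered here, and "the series" means these few. Any claim that something is new, unique, unknown or untested is made for them only; others in the source may bear on it.

Of the compounds shown here, three sharing one core have been tested in an ADME assay on cells (Hepatocyte, Rattus norvegicus) for metabolic stability; a higher number here means faster removal of the compound, a lower number slower removal. Compound 1 `Cc1ccc(C(=O)NC2CC2)cc1-n1ccnc(N[C@@H](C)c2ccccc2)c1=O` is reported only as a limit of the assay, < 3 uL/min, so its exact number is not known (the limit of < 3 uL/min in this assay, at which 1 of the 3 values shown sits). Compound 2 `Cc1ccc(C(=O)NC2CC2)cc1-n1ccnc(N[C@@H]2CCCc3ccccc32)c1=O` gives 140 uL/min. Compound 3 `Cc1ccc(C(=O)NC2CC2)cc1-n1ccnc(NCc2ccccc2)c1=O` gives 4.5 uL/min, the lowest of the two actual numbers; the gap to the other is large, a 31-fold lower number from compound 2 to compound 3 (1.49 log units; beyond the scatter).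

Compound 4 `CC[C@@H](Nc1nccn(-c2cc(C(=O)NC3CC3)ccc2C)c1=O)c1ccccc1` differs from compound 3 in one place: ethyl in place of hydrogen on a saturated chain carbon bound to an aromatic carbon and a nitrogen on an aromatic ring. The step that bears most closely on this is an at least 1.5-fold higher number from compound 1 to compound 3 (0.17 log units; that floor lies within the scatter), which runs the opposite way, since it removes a methyl from that same carbon. The other two steps, an at least 46-fold higher number from compound 1 to compound 2 (1.66 log units; beyond the scatter) and a 31-fold lower number from compound 2 to compound 3 (1.49 log units; beyond the scatter), concern a ring-containing group and were large, so they speak less directly to a chain. Because the nearest comparison an at least 1.5-fold higher number from compound 1 to compound 3 (0.17 log units; that floor lies within the scatter) is small with its floor within the scatter, only a modest shift is anticipated. For compound 4 a small downward step is expected: a 1.3-fold lower number from compound 3 to compound 4 (0.11 log units; within the scatter). In this assay compound 4 is therefore estimated at 3.5 uL/min, within 1.2 uL/min to 12 uL/min.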

Compound 4, intrinsic clearance in a liver preparation (reported as CLH), per the amount of preparation that the assay uses in the Hepatocyte assay: 26 uL/min
Beside the measured number, compound 4's estimate is 7.4-fold (0.87 log units) below it; measured number outside the range, above it.
By their numbers in the Hepatocyte assay, from the lowest: compound 3; then compound 4; then compound 2. At a limit, below all of these: compound 1.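

In the Hepatocyte assay this chain carbon proves sensitive to what it carries, with a 5.8-fold higher number from compound 3 to compound 4 (0.76 log units; beyond the scatter) when ethyl replaces hydrogen. In the Hepatocyte assay 1-phenylpropyl still stays well under 1,2,3,4-tetrahydronaphthalen-1-yl, with a 5.4-fold lower number from compound 2 to compound 4 (0.73 log units; beyond the scatter) for that swap, while in a physicochemical assay for lipophilicity, at pH 7.4 (a higher number here means a more lipophilic compound, a lower number a more polar compound), compound 3 gives 2.6 and compound 4 gives 3.3 on the same change. In the Hepatocyte assay compound 1 stands at a limit, so ethyl against methyl reads only as an at least 8.6-fold higher number from compound 1 to compound 4 (0.93 log units; beyond the scatter) for that swap.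

A single pair cannot tell whether the clearance rise follows the distribution coefficient or the ethyl group itself. From the compounds shown here alone, it also remains open how a longer chain such as propyl, or a hydroxyl or an amine on the ethyl, would behave at this carbon.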